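Cyclopropyl in place of isopropyl: compound 4 awaits measurement

The source may hold more compounds than are shown below. What is called first, only, known or untested is meant among the compounds shown, and "the series" means these compounds.

Values so far in an ADME assay on microsomes from liver (Mus musculus) for metabolic stability, read by LC-MS, with a stated time of 10 min, tested at 0.5 uM; on this read-out higher numbers stand for a more stable compound and lower numbers for a less stable compound

Compound 1 `CC(C)N1CCN(CCCN(C[C@H]2Cc3ccccc3CN2)[C@H]2CCCc3cccnc32)CC1` gives 58%
Compound 2 `c1cnc2c(c1)CCC[C@@H]2N(CCCN1CCNCC1)Cc1cc2ccccc2cn1` gives 74%
Compound 3 `c1cnc2c(c1)CN[C@@H](CN(CCCN1CCNCC1)[C@H]1CCCc3cccnc31)C2` gives 78%

Compound 1 has the lowest number of the three, and compound 2 and compound 3 both stand above it beyond the scatter. Compound 4 `c1ccc2c(c1)CN[C@@H](CN(CCCN1CCN(C3CC3)CC1)[C@H]1CCCc3cccnc31)C2` has not yet been measured. It departs from compound 1 by cyclopropyl in place of isopropyl on an amine nitrogen in a ring with cyclopropyl in place of isopropyl on an amine nitrogen in a ring. Among the compounds with values here, no measured step makes this exchange. Within the data shown here, the only one available is a number 4 percentage points higher from compound 2 to compound 3 (within the scatter) and it concerns a different group, so it offers weak guidance. The expected step in this assay is a number 4 percentage points higher from compound 1 to compound 4 (within the scatter) and thus nothing beyond the scatter. For compound 4 the estimated value is 62% with 47% to 76% as the expected range.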

Compound 4, percent of the compound remaining: 3%
Beside the measured number, compound 4's estimate is 59 percentage points above it; measured number outside the range, below it.
By their numbers in this assay, from the lowest: compound 4; then compound 1; then compounds 2 and 3 (each within the scatter of the next).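

In this assay the group on the amine nitrogen in the ring proves decisive: cyclopropyl in place of isopropyl gives a number 55 percentage points lower from compound 1 to compound 4 (beyond the scatter), although both groups hold the same count of carbon atoms and differ only in the closed ring. Within the data shown here, no earlier step touched this position, so its large effect on the read-out could not be seen before. Nothing at hand accounts for the drop.

This single pair leaves open whether the fall is peculiar to cyclopropyl. How an ethyl, a tert-butyl or a cyclobutyl group would read on the same nitrogen remains an open question.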